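The source may report more compounds than this note shows. Statements on the series, on what has been measured and on what is new or still open speak of the compounds shown alone.

Compound 1 `Cc1cc(C)c(NC(=O)N(Cc2ccc(-c3nnc(C)o3)cc2)C2CCCCCC2)c(C)c1` was examined in a functional assay on a cell-free system (plasma) with sterol O-acyltransferase, Soat (Rattus norvegicus) as the target; on this read-out lower numbers stand for an effect already at smaller amounts and higher numbers for an effect only at larger amounts of compound. In this assay compound 1 gave no number but only a limit of the assay, > 0.32 mg/kg. Compound 2 `Cc1cc(C)c(NC(=O)N(Cc2ccccc2)Cc2cccc(-c3cc[nH]n3)c2)c(C)c1` likewise gave only a limit in this assay, > 1 mg/kg. Compound 3 `O=C(Nc1c(F)cc(F)cc1F)N(Cc1ccc(-n2cccc2)cc1)C1CCCCCC1` also reached nothing more than a limit in this assay, > 1 mg/kg. Compound 1 thus stands at the limit of > 0.32 mg/kg in this assay, at which 1 of the 3 values shown sits, whereas the two others sit at the limit of > 1 mg/kg in this assay, at which 2 of the 3 values shown sit. Among the measured compounds shown here, since every value shown is a limit, none of the three can be placed in order against the others, and no step between measured compounds can be stated in this assay.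

Compound 4 `Cc1cc(C)c(NC(=O)N(Cc2ccc(-c3ccnn3C)cc2)C2CCCCCC2)c(C)c1` differs from compound 1 in one place: 1-methyl-1H-pyrazol-5-yl in place of 5-methyl-1,3,4-oxadiazol-2-yl on an aromatic carbon. For the measured compounds named here, no measured pair shows what such an exchange does in this assay, so any expectation for compound 4 rests on where compound 1 itself stands. With compound 1 resting only at a limit in this assay, the estimated step that the limit leaves unreadable from compound 1 to compound 4 is expected to be none beyond the usual scatter. Compound 4 is therefore expected to give in this assay an estimate of 1 mg/kg, within a range from 0.3 mg/kg to 3 mg/kg, and it is expected that the assay may again report only a limit.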

Compound 4, dose for half-maximal effect: < 1 mg/kg
Compound 4: only a limit was reported; the forecaster's own chance of this, stated with the estimate: 70%; the middle value lies on the limit itself.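

Among the compounds shown here, compound 1 and compound 4 both rest only on limits in this assay, so no step between them can be read. The compounds shown leave open what actual value either compound would reach, and how far, or in which direction, 1-methyl-1H-pyrazol-5-yl in place of 5-methyl-1,3,4-oxadiazol-2-yl on an aromatic carbon shifts the effect.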